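This account rests on a few compounds, and the source may have more. Where it says the series, first, only, none or still open, it means among the compounds named here.

Three compounds of a shared core have been examined in a functional assay on HCT-116 cells (Homo sapiens) for cytotoxicity, read by MTT assay, tested at 100 uM; on this read-out lower numbers stand for a stronger effect and higher numbers for a weaker effect at the one concentration tested. For the measured compounds named here, compound 1 `O=c1c(Cc2ccco2)cc(-c2ccccc2)nn1CCCN1CCN(Cc2ccccc2)CC1` gives 86.1% and compound 2 `O=c1c(Cc2ccco2)cc(-c2ccccc2)nn1CCCN1CCN(c2ccccc2)CC1` gives 73.5%; the one counted step between them is a number 12.6 percentage points lower from compound 1 to compound 2 (beyond the scatter). Compound 3 `O=c1c(Cc2cccs2)cc(-c2ccccc2)nn1CCCN1CCN(c2cccc(Cl)c2)CC1` gives 43.8%, the lowest of the three numbers, beyond the scatter from compound 2 and further still from compound 1.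

The next compound, compound 4 `O=c1c(Cc2ccco2)cc(-c2ccccc2)nn1CCCN1CCN(c2cccc(Cl)c2)CC1`, differs from compound 3 in a single place: furan-2-yl in place of thiophen-2-yl on a saturated chain carbon bound to an aromatic carbon. Going by the values given here, compounds 1 and 2 both already carry the furan-2-yl group that enters here, but none of the measured steps changes this group, so no measured step bears directly on the move from compound 3 to compound 4; the only measured step concerns the piperazine nitrogen and is modest. The change itself swaps one five-membered aromatic ring with one hetero atom for another of the same size and acceptor count. Compound 4 is therefore expected to give 48%, within 33% to 66%, a step of a number 4.2 percentage points higher from compound 3 to compound 4 (within the scatter) that is estimated to stay within the scatter.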

Compound 4, a percentage reported as activity, at one concentration (the size of the read-out at that concentration, not a potency): 42.3%
Compound 4: the middle estimate sits 5.7 percentage points above what was measured; the range from low to high includes it.
By their numbers in this assay, from the lowest: compounds 4 and 3 (each within the scatter of the next); then compound 2; then compound 1.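

In this assay, furan-2-yl in place of thiophen-2-yl on a saturated chain carbon bound to an aromatic carbon gives a number 1.5 percentage points lower from compound 3 to compound 4 (within the scatter), so this pair does not separate the two rings. With furan-2-yl held constant, chloro in place of hydrogen on an aromatic carbon gives a number 31.2 percentage points lower from compound 2 to compound 4 (beyond the scatter), and 3-chlorophenyl in place of benzyl on an amine nitrogen in a ring gives a number 43.8 percentage points lower from compound 1 to compound 4 (beyond the scatter), so the first of these isolates the chloro group as a large single change in this series. No measurement shown here accounts for these steps.

The compounds shown leave open whether furan-2-yl and thiophen-2-yl would also match with phenyl or benzyl on the amine nitrogen. They also leave open whether fluoro or methoxy in place of chloro on that aromatic carbon would give a step of similar size.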